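The source may report more compounds than this note shows. Statements on the series, on what has been measured and on what is new or still open speak of the compounds shown alone.

Of the compounds shown here, three have been measured so far in a functional assay on RAW264.7 cells (Mus musculus) for inhibition, read by Griess assay, with a stated time of 24 h (on this read-out lower numbers stand for stronger inhibition and higher numbers for weaker inhibition), with compound 1 (`CC(C)=C1C[C@H]2[C@@H](CC[C@]2(C)O)C(CO)=CC1=O`) giving a value of (12900 nM). Compound 2 (`C=C1C[C@]2(O)O[C@@]3(CC2=C(C)C)[C@@H](C)CC[C@@H]13`) gives (9800 nM), which lies within the scatter of compound 1, so the two cannot be told apart. Compound 3 (`CC1=CC(=O)[C@@]2(C[C@]3(O)[C@@H](C)CC[C@@H]13)OC2(C)C`) gives (57400 nM), a number beyond the scatter from compound 1 and so weaker inhibition. Compound 1 therefore stands level with compound 2, at the stronger end of this small set.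

The next compound, compound 4 (`CC1=CC(=O)C(=C(C)C)C[C@H]2[C@H]1CC[C@]2(C)O`), keeps the core of compound 1 and differs in one place (hydrogen in place of hydroxy on a saturated chain carbon bound to a double-bonded ring carbon). Hydrogen stands in place of hydroxy on a saturated chain carbon bound to a double-bonded ring carbon, which turns a hydroxymethyl into a methyl. Going by the values given here, no two measured compounds differ in only one place, so the data offer no direct guide to this change. Compound 2 and compound 3 also lack the hydroxymethyl, yet their values are far apart, so its absence alone does not settle the number. In this assay no step beyond the scatter is expected, and no direction is favoured, with the estimated change (a 1.1-fold higher number from compound 1 to compound 4 (0.04 log units; within the scatter)) staying small. For compound 4 the expected value is 14000 nM with an estimated range from 6000 nM to (35000 nM).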

Compound 4, half-maximal inhibitory concentration: 13700 nM
Compound 4: the middle estimate sits 1.0-fold (0.01 log units) above what was measured, within the range that was stated.
By their numbers in this assay, from the lowest: compounds 2, 1 and 4 (each within the scatter of the next); then compound 3.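

In this assay, the exchange of hydroxymethyl for methyl on the shared core comes out as a 1.1-fold higher number from compound 1 to compound 4 (0.03 log units; within the scatter), so the two compounds cannot be told apart. Going by these compounds alone, this is the first direct comparison at this place, on a saturated chain carbon bound to a double-bonded ring carbon, and it shows that the hydroxy there can give way to hydrogen with no difference that this read-out can resolve. No measurement at hand explains this outcome.

The compounds shown compare only hydroxymethyl and methyl at this place, so it remains open whether the same carbon would accept something quite different, such as a carboxylic acid, an amine or a longer chain, and whether any such group would move the number beyond the scatter in either direction. Going by these compounds, it also remains open whether the same exchange would prove just as silent on the different cores of compound 2 and compound 3, since neither has a partner that differs from it in one place.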